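The source may hold more compounds than are shown below. What is called first, only, known or untested is meant among the compounds shown, and "the series" means these compounds.

In an ADME assay on HepG2 cells (Homo sapiens) for cytotoxicity (on this read-out lower numbers stand for higher toxicity in this test and higher numbers for lower toxicity in this test), three compounds have been measured so far. Compound 1 (`CSc1cccc(N2C(=O)CN(c3ccc(C(F)(F)F)cc3)CC2C(=O)NC2CCCC2)c1`) gives 10000 nM, compound 2 (`O=C(NC1CCCC1)[C@H]1CN(c2ccc(C(F)(F)F)cc2)CC(=O)N1c1ccc2ccsc2c1`) gives 10000 nM and compound 3 (`O=C(NC1CCCC1)[C@@H]1CN(c2ccc(C(F)(F)F)cc2)CC(=O)N1c1ccc2ccsc2c1`) gives 20000 nM. The number for compound 3 lies within the usual scatter of both other numbers, so this test does not separate it from either of them.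

The next compound to be measured is compound 4 (`O=C(NC1CCCC1)C1CN(c2ccc(C(F)(F)F)cc2)CC(=O)N1c1ccc2ccsc2c1`). Its structure differs from that of compound 3 in one respect: the two compounds have the same atoms and bonds; at least one stereo element is drawn with a configuration in one of them and without one in the other: 1 of 1 stereo elements differ; a stereocentre at a saturated ring carbon is drawn S in compound 3 and without a configuration in compound 4. No group leaves or enters, and the change concerns only how that saturated ring carbon is drawn.

Going by the values given here, one measured step bears on this carbon, and it is a 2.0-fold higher number from compound 2 to compound 3 (0.30 log units; within the scatter). That comparison rests on (the fact that compounds 2 and 3 differ only in the configuration as drawn), which makes it a direct look at this stereocentre, and the step stays within the scatter. Drawing the same carbon without a configuration therefore gives no reason to expect a step beyond the scatter in this assay, in either direction.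

The estimate means a 1.4-fold lower number from compound 3 to compound 4 (0.15 log units; within the scatter), which is expected to be within the scatter. For compound 4 the expected value is 14000 nM, with an estimated range from 7000 nM to 28000 nM.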

Compound 4, half-maximal cytotoxic concentration: 10000 nM
For compound 4 the middle estimate is 1.4-fold (0.15 log units) above the measured one, and the stated range covers the measured number.
By their numbers in this assay, from the lowest: compounds 1, 2, 4 and 3 (each within the scatter of the next).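

In this assay, the drawing without a configuration at this saturated ring carbon can now be set against both drawn configurations, giving a 2.0-fold lower number from compound 3 to compound 4 (0.30 log units; within the scatter) and no change at the digits printed from compound 2 to compound 4 (within the scatter), so this test separates compound 4 from neither compound 2 nor compound 3. Both steps bear on this carbon alone, and the comparison with compound 3 shows how directly, since no group leaves or enters: the fact that one of compounds 3 and 4 is drawn with a defined configuration and the other without, at the place where they differ. Compound 4 also adds a comparison at a second place, where 1-benzothiophen-6-yl stands in place of 3-(methylsulfanyl)phenyl on the amide-type nitrogen, and no change at the digits printed from compound 1 to compound 4 (within the scatter) means that this exchange, too, stays unresolved by this test.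

The data do not tell what mixture of the two configurations compound 4 contains, so its number cannot be assigned to either form. All four compounds also keep the cyclopentyl group on the amide, which leaves open whether an amine or a carboxylic acid at that place would give a step beyond the scatter in this assay.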